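Predicting Compound 4 from Three Measured Analogues

This account rests on a few compounds, and the source may have more. Where it says the series, first, only, none or still open, it means among the compounds named here.

Measured so far:
compound 1 `O=C(/C=C/C1=Cc2ccccc2OC1)c1cccc(F)c1`: 52.4%
compound 2 `O=C(/C=C/C1=Cc2ccccc2OC1)c1ccc(F)cc1`: 65.6%
compound 3 `O=C(/C=C/C1=Cc2ccccc2OC1)c1ccc(C(F)(F)F)cc1`: 75.5%

In a functional assay on the whole organism for inhibition, with Mus musculus as the target, with a stated time of 1 h, at a dose of 30 mg/kg by the intraperitoneal route (a lower number here means less inhibition, a higher number more inhibition at the dose given (going by the name of the read-out)), compound 1 gives 52.4%, the lowest of the three numbers. The step of a number 13.2 percentage points higher from compound 1 to compound 2 (beyond the scatter) lies beyond the scatter, while the step of a number 9.9 percentage points higher from compound 2 to compound 3 (within the scatter) lies within it. Compound 4 `Cc1ccc(C(=O)/C=C/C2=Cc3ccccc3OC2)cc1` has not yet been measured. It differs from compound 1 by 4-methylphenyl in place of 3-fluorophenyl on a carbonyl carbon. The step that bears most directly on this change is a number 13.2 percentage points higher from compound 1 to compound 2 (beyond the scatter), which also exchanges the 3-fluorophenyl for a phenyl carrying a single substituent at the 4-position; the step of a number 9.9 percentage points higher from compound 2 to compound 3 (within the scatter) adds little beyond the scatter. A modest rise in this assay is therefore expected. Compound 4 is estimated at 62%, within a range of 48% to 76%. For compound 4 this means an expected step of a number 9.6 percentage points higher from compound 1 to compound 4 (within the scatter).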

Compound 4, a percentage reported as inhibition, in the whole organism at one dose (the size of the read-out at that dose, not a potency): 53.1%
Compound 4: the middle estimate sits 8.9 percentage points above what was measured; the range from low to high includes it.
By their numbers in this assay, from the lowest: compounds 1 and 4 (each within the scatter of the next); then compounds 2 and 3 (each within the scatter of the next).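

With 4-methylphenyl in place of 3-fluorophenyl on the carbonyl carbon, the result is a number 0.7 percentage points higher from compound 1 to compound 4 (within the scatter), so moving to a 4-substituted phenyl does not by itself reproduce the rise seen with 4-fluorophenyl. The identity of the group on the aromatic carbon matters: methyl in place of fluoro gives a number 12.5 percentage points lower from compound 2 to compound 4 (beyond the scatter), and methyl in place of trifluoromethyl gives a number 22.4 percentage points lower from compound 3 to compound 4 (beyond the scatter). No evidence is available to explain these differences. As far as these compounds go, whether a methoxy group or an amine on that aromatic carbon would match methyl or the two fluorinated groups remains open.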